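Carbamate in place of acyl azide on the shared core

A few compounds are considered here, and "the series" means these few. Any claim that something is new, unique, unknown or untested is made for them only; others in the source may bear on it.

Working notes. Among the measured compounds shown here, compound 1 `Cc1c(C(=O)N=[N+]=[N-])[n+]([O-])c2cc(Cl)ccc2[n+]1[O-]` gives 92.6% in a functional assay on Ehrlich cells (Mus musculus) for cytotoxicity, read by trypan blue exclusion, with a stated time of 2 h, tested at 5 ug/mL (on this read-out higher numbers stand for a weaker effect at the one concentration tested and lower numbers for a stronger effect), the highest of the two numbers so far; its nearest neighbour is compound 2 `COc1ccc2c(c1)[n+]([O-])c(C(=O)N=[N+]=[N-])c(C)[n+]2[O-]` with 81.1%, a step of a number 11.5 percentage points lower from compound 1 to compound 2 (beyond the scatter). Compound 3 `Cc1c(NC(=O)OC(C)C)[n+]([O-])c2cc(Cl)ccc2[n+]1[O-]` differs from compound 1 by a group of 7 heavy atoms (4 carbon, 1 nitrogen, 2 oxygen; no ring) in place of a group of 5 heavy atoms (1 carbon, 3 nitrogen, 1 oxygen; no ring), on an aromatic carbon. For the measured compounds named here, no measured step touches this position; the only step known is the change of chloro to methoxy, which gives no guide. A step of a number 5.6 percentage points lower from compound 1 to compound 3 (within the scatter) is therefore expected, within or near the scatter. Compound 3 is estimated at 87%, between 68% and 100%.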

Compound 3, a percentage reported as activity, at one concentration (the size of the read-out at that concentration, not a potency): 98.3%
Compound 3: middle estimate off by 11.3 percentage points, on the low side; measured number inside the range.
By their numbers in this assay, from the lowest: compound 2; then compounds 1 and 3 (each within the scatter of the next).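

Among the compounds shown here, the first comparison at this position, in this assay, reads a number 5.7 percentage points higher from compound 1 to compound 3 (within the scatter): with chloro on the shared core, this read-out does not tell the (isopropoxycarbonyl)amino group from the acyl azide on the aromatic carbon next to the ring nitrogen. The acyl azide is thus not required for the number seen with compound 1. No supporting data bear on why the two groups read alike.

From the compounds shown here alone, whether the same exchange holds on the core of compound 2 remains open. So does whether a free amine or a carboxylic acid at this position would give a number beyond the scatter.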